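Methoxy in Place of Bromo at the Same Aromatic Carbon

A few compounds are considered here, and "the series" means these few. Any claim that something is new, unique, unknown or untested is made for them only; others in the source may bear on it.

Compound 1 `CO[C@@H]1[C@H](N(C)c2ncc(-c3c[nH]c4ccccc34)s2)C[C@H]2O[C@]1(C)n1c3ccccc3c3c4c(c5c6cc(Cl)ccc6n2c5c31)C(=O)NC4` and compound 2 `CO[C@@H]1[C@H](N(C)c2ncc(-c3c[nH]c4ccc(Br)cc34)s2)C[C@H]2O[C@]1(C)n1c3ccccc3c3c4c(c5c6cc(Cl)ccc6n2c5c31)C(=O)NC4` share one core and differ only at a single aromatic carbon. In a functional assay on MV4-11 cells (Homo sapiens) for antiproliferative activity, read by CellTiter-Glo, with a stated time of 72 h (a higher number here means a weaker inhibitor, a lower number a stronger inhibitor), compound 1 gives 560 nM, and compound 2 gives 430 nM. The step of a 1.3-fold lower number from compound 1 to compound 2 (0.11 log units; within the scatter) shows that bromo in place of hydrogen moved the number only within the scatter. Compound 2 thus stands at the lower of the two numbers, but it cannot be separated from compound 1 beyond the scatter.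

Compound 3 `COc1ccc2[nH]cc(-c3cnc(N(C)[C@@H]4C[C@H]5O[C@@](C)([C@@H]4OC)n4c6ccccc6c6c7c(c8c9cc(Cl)ccc9n5c8c64)C(=O)NC7)s3)c2c1` carries the change (methoxy in place of bromo on an aromatic carbon), methoxy in place of bromo on an aromatic carbon. Within the data shown here, the only measured step that touches this carbon is a 1.3-fold lower number from compound 1 to compound 2 (0.11 log units; within the scatter), and it was small. Nothing measured separates methoxy from bromo at this carbon, so there is no ground for a large move in either direction. The expectation for compound 3 is a step of a 1.0-fold higher number from compound 2 to compound 3 (0.02 log units; within the scatter) in this assay, lying within the scatter. Compound 3 is therefore estimated at 450 nM, with a range from 200 nM to 1000 nM.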

Compound 3, half-maximal inhibitory concentration: 440 nM
For compound 3 the middle estimate is 1.0-fold (0.01 log units) above the measured one, and the stated range covers the measured number.
By their numbers in this assay, from the lowest: compounds 2, 3 and 1 (each within the scatter of the next).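

In this assay the swap of 5-bromo-1H-indol-3-yl for 5-methoxy-1H-indol-3-yl gives a 1.0-fold higher number from compound 2 to compound 3 (0.01 log units; within the scatter) even though one heavy atom leaves, two enter and a hydrogen-bond acceptor is added, so bromo and methoxy cannot be told apart at this carbon. Compound 2 alone had shown only that one group, bromo, could replace hydrogen here without a move beyond the scatter; methoxy in place of hydrogen now gives a 1.3-fold lower number from compound 1 to compound 3 (0.10 log units; within the scatter) as well, which makes two different groups at this carbon that cannot be separated from hydrogen across these three compounds. Nothing available bears on why this carbon reads the same with all three groups.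

The three compounds leave open whether the number would stay as flat with a quite different group at this carbon, such as an amine or a carboxylic acid. They also leave open whether this assay would read the same for substituents on the other carbons of this six-membered ring.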